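Diaryl urea series: aryl swap on the urea nitrogen

The source may report more compounds than this note shows. Statements on the series, on what has been measured and on what is new or still open speak of the compounds shown alone.

Compound 2 `O=C(Nc1ccc(Oc2ccc(-c3nccs3)cc2)cc1)Nc1cccc(C(F)(F)F)c1` is the higher of the two measured ureas in a functional assay on MDA-MB-231 cells (Homo sapiens) for inhibition, read by MTT assay and WST assay, with a stated time of 72 h, tested at 10 uM (a lower number here means less inhibition of growth, a higher number more inhibition of growth at the concentration tested), giving 64.1%. Compound 1 `O=C(Nc1ccc(Cl)cc1)Nc1ccc(Oc2ccc(-c3nccs3)cc2)cc1` sits below it in this assay, giving 32.5%. Among the measured compounds shown here, the only measured step is the exchange of the aryl group on the amide-type nitrogen, which gave a number 31.6 percentage points higher from compound 1 to compound 2 (beyond the scatter).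

Compound 3 `Cc1ccc(NC(=O)Nc2ccc(Oc3ccc(-c4nccs4)cc3)cc2)cc1` changes the same position: 4-methylphenyl in place of 3-(trifluoromethyl)phenyl on an amide-type nitrogen. For the measured compounds named here, no measured pair bears on 4-methylphenyl itself, so the only guide is the single step from compound 1 to compound 2, which shows that the identity of this aryl group moves the number well beyond the scatter. The group entering in compound 3 is closer in kind to the 4-chlorophenyl of compound 1 than to the 3-(trifluoromethyl)phenyl of compound 2, so a step back toward the value of compound 1 is expected, of size a number 28.1 percentage points lower from compound 2 to compound 3 (beyond the scatter). Going by the values given here, for compound 3 the expected result in this assay is therefore 36%, with a range from 16% to 56%; the wide range reflects that only one relevant step is known.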

Compound 3, percent growth inhibition at one concentration: 22.8%
Beside the measured number, compound 3's estimate is 13.2 percentage points above it, within the range that was stated.
By their numbers in this assay, from the lowest: compounds 3 and 1 (each within the scatter of the next); then compound 2.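

In this assay, the step to 4-methylphenyl gives a number 41.3 percentage points lower from compound 2 to compound 3 (beyond the scatter), so a second replacement for 3-(trifluoromethyl)phenyl on this amide-type nitrogen also lies far from the higher number. Methyl in place of chloro on an aromatic carbon gives a number 9.7 percentage points lower from compound 1 to compound 3 (within the scatter), so 4-chlorophenyl and 4-methylphenyl are not separated by this read-out, and among these three ureas only the 3-(trifluoromethyl)phenyl group stands clear of the others. No measurement is available here that offers an explanation for these differences.

The two aryl groups that sit low and the one that sits high differ both in the substituent and in the number in the group name, so these compounds do not show which of the two goes with the higher growth inhibition. From the compounds shown here alone, whether a plain phenyl, or an aryl group carrying a nitrile or a methoxy group, would stay with the low pair or approach the 3-(trifluoromethyl)phenyl urea remains open, as does the effect of any change to the shared core.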